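A few compounds are considered here, and "the series" means these few. Any claim that something is new, unique, unknown or untested is made for them only; others in the source may bear on it.

In a functional assay on U-87MG ATCC cells for antiproliferative activity against U-87 MG (Homo sapiens), read by MTT assay, with a stated time of 48 h (a lower number here means a stronger inhibitor, a higher number a weaker inhibitor), three compounds sharing one core have been measured: compound 1 `Cc1nc(-c2ccc(Cl)cc2)sc1C(=O)CSc1nc(-c2ccc(Cl)c(Cl)c2)c(C#N)c(=O)[nH]1` gives 83900 nM, compound 2 `Cc1nc(-c2ccccc2)sc1C(=O)CSc1nc(-c2ccc(Cl)c(Cl)c2)c(C#N)c(=O)[nH]1` gives 65000 nM, and compound 3 `COc1ccc(-c2nc(C)c(C(=O)CSc3nc(-c4ccc(Cl)c(Cl)c4)c(C#N)c(=O)[nH]3)s2)cc1` gives 68500 nM. Compound 1 therefore stands within the scatter of both of the others, and the three values cannot be ranked.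

Compound 4 `Cc1nc(-c2ccc(Cl)cc2)sc1C(=O)CSc1nc(-c2ccc(Cl)cc2)c(C#N)c(=O)[nH]1` departs from compound 1 by one change, (hydrogen in place of chloro on an aromatic carbon), which turns 3,4-dichlorophenyl into 4-chlorophenyl. All three measured compounds keep the 3,4-dichlorophenyl group, so no measurement tests this position directly.

The closest evidence is the same exchange of hydrogen in place of chloro on an aromatic carbon elsewhere in the molecule, a 1.3-fold lower number from compound 1 to compound 2 (0.11 log units; within the scatter). Methoxy in place of chloro at that site gave a 1.2-fold lower number from compound 1 to compound 3 (0.09 log units; within the scatter), and methoxy in place of hydrogen gave a 1.1-fold higher number from compound 2 to compound 3 (0.02 log units; within the scatter). All three steps stay within the scatter, but they show only how tolerant that other site is.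

On this limited evidence, no shift beyond the scatter is expected in this assay, and no direction can be favoured. The estimated step is a 1.2-fold lower number from compound 1 to compound 4 (0.08 log units; within the scatter). For compound 4 the estimated value is 70000 nM, with an expected range from 32000 nM to 150000 nM.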

Compound 4, half-maximal inhibitory concentration: 53000 nM
Beside the measured number, compound 4's estimate is 1.3-fold (0.12 log units) above it, within the range that was stated.
By their numbers in this assay, from the lowest: compounds 4, 2, 3 and 1 (each within the scatter of the next).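

In this assay, going by these compounds alone, this position now has a direct reading for the first time: going from 3,4-dichlorophenyl to 4-chlorophenyl, with hydrogen entering on the aromatic carbon ortho to a chloro group, gives a 1.6-fold lower number from compound 1 to compound 4 (0.20 log units; within the scatter). The earlier compounds shown here varied only the other aryl site, so they could say nothing about this chloro group, and the new pair cannot be told apart within the scatter. Hydrogen in place of chloro now stays within the scatter at both sites, as the other site's a 1.3-fold lower number from compound 1 to compound 2 (0.11 log units; within the scatter) shows, although this is a statement about two single exchanges on the core of compound 1 and not a general rule. No available evidence bears on why this exchange leaves the reading within the scatter.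

At this position, the compounds shown hold only chloro and hydrogen, so they leave open whether an amine, a carboxylic acid or a methoxy group there would move the number beyond the scatter. They also leave open what happens when the remaining chloro group on this ring is replaced by hydrogen.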